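The source may hold more compounds than are shown below. What is called first, only, known or untested is meant among the compounds shown, and "the series" means these compounds.

Measured compounds:
compound 1 `CCCSc1nc(N/N=C(\C)c2ccccc2O)c2nnn(Cc3ccco3)c2n1` — 5760 nM
compound 2 `CCCSc1nc(N/N=C/c2ccc(C)cc2)c2nnn(Cc3ccccc3)c2n1` — > 64000 nM
compound 3 `C#CCSc1nc(N/N=C/c2cc(OC)c(OC)c(OC)c2)c2nnn(Cc3ccccc3)c2n1` — 6540 nM

All three were tested in a functional assay on ECa-109 cells (Homo sapiens) for antiproliferative activity, read by MTT assay, with a stated time of 72 h; a lower number here means a stronger inhibitor, a higher number a weaker inhibitor. Compound 1 gives 5760 nM, and compound 3 gives 6540 nM; these two values lie within the usual scatter of each other, so neither can be called the stronger. Compound 2 is different: in this assay compound 2 reaches only > 64000 nM, which is a limit of the assay and not a measured number. It is the one compound of the three that sits at the limit of > 64000 nM in this assay, at which 1 of the 3 values shown sits, so all that can be said of compound 2 is that it is the weakest inhibitor among the three shown.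

The next compound, compound 4 `CCCSc1nc(N/N=C/c2c(O)ccc3ccccc23)c2nnn(Cc3ccccc3)c2n1`, has not yet been measured in this assay. It differs from compound 2 in one place: 2-hydroxynaphthalen-1-yl in place of 4-methylphenyl on a carbon with a double bond to nitrogen. Among the compounds with values here, since compound 2 offers only a limit, no measured step of this kind is available, and the size of the change is therefore a matter of expectation alone. The expectation is that compound 4 moves clearly toward stronger inhibition, by an at least 8.0-fold lower number from compound 2 to compound 4 (0.90 log units; beyond the scatter), well beyond the scatter. Compound 4 is estimated at 8000 nM, with a plausible range from 2500 nM to 40000 nM.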

Compound 4, half-maximal inhibitory concentration: 9290 nM
For compound 4 the middle estimate is 1.2-fold (0.06 log units) below the measured one; the measured number falls inside the stated range.
By their numbers in this assay, from the lowest: compounds 1, 3 and 4 (each within the scatter of the next). At a limit, above all of these: compound 2.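

In this assay, 2-hydroxynaphthalen-1-yl in place of 4-methylphenyl on a carbon with a double bond to nitrogen gives an at least 6.8-fold lower number from compound 2 to compound 4 (0.83 log units; beyond the scatter), the first step that can be read among the compounds shown. Within the data shown here, compound 2 sits at a limit of the assay and not at a number, so this step gives only a smallest possible size, and the true change may be larger: the limit of > 64000 nM in this assay, at which 1 of the 4 values shown sits. The earlier compounds could not show this, as no two of them differed in one place only; here the rest of the molecule stays the same, and changing the group at this one place is enough to bring a compound from the limit to a measured value.

The entering group brings a second aromatic ring and a hydroxy group at once, so the compounds shown leave open which of the two goes with the change. A naphthalene ring with no hydroxy group, or one with an amine in place of the hydroxy group, would be needed to separate the two.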